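This account rests on a few compounds, and the source may have more. Where it says the series, first, only, none or still open, it means among the compounds named here.

Measured compounds:
compound 1 `CN1CCN(c2nc(Nc3ccc(C#N)c(C(F)(F)F)c3)nc(Oc3ccnc4ccccc34)n2)CC1` — > 100000 nM
compound 2 `N#Cc1ccc(Nc2nc(Oc3ccnc4ccccc34)nc(N3CCN(c4cccc(C(F)(F)F)c4)CC3)n2)cc1C(F)(F)F` — 74100 nM
compound 3 `CCN1CCN(c2nc(Nc3ccc(C#N)c(C(F)(F)F)c3)nc(Oc3ccnc4ccccc34)n2)CC1` — > 100000 nM

In a functional assay on DU-145 cells (Homo sapiens) for cytotoxicity, read by sulforhodamine B assay, with a stated time of 48 h (on this read-out higher numbers stand for weaker inhibition of growth and lower numbers for stronger inhibition of growth), compound 3 sits at a limit, > 100000 nM. Compound 1 also sits at that limit, (the limit of > 100000 nM in this assay, at which 2 of the 3 values shown sit). Compound 2 gives a number, 74100 nM. Compound 4 `COc1ccc(CN2CCN(c3nc(Nc4ccc(C#N)c(C(F)(F)F)c4)nc(Oc4ccnc5ccccc45)n3)CC2)c(OC)c1OC` differs from compound 3 in 2,3,4-trimethoxyphenyl in place of methyl on a saturated chain carbon bound to an amine nitrogen in a ring. Within the data shown here, the only step at this place, a step that the two limits leave unreadable from compound 1 to compound 3, is unreadable; the steps of an at least 1.3-fold lower number from compound 1 to compound 2 (0.13 log units; that floor lies within the scatter) and an at least 1.3-fold higher number from compound 2 to compound 3 (0.13 log units; that floor lies within the scatter) concern a different place and lie within the scatter. No step beyond the scatter is therefore expected in this assay. Compound 4 is estimated at 90000 nM, range 35000 nM to 250000 nM, with a fair chance that again only a limit is reported. That estimate means an at least 1.1-fold lower number from compound 3 to compound 4 (0.04 log units; that floor lies within the scatter).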

Compound 4, concentration for total growth inhibition: > 100000 nM
Compound 4: a limit, no number; the forecaster's own chance of this, stated with the estimate: 55%; middle value at least 1.1-fold (0.04 log units) away from the limit.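

Compound 4 gives > 100000 nM in this assay, a limit and not a number. No step from compound 1 or compound 3 to compound 4 can be read: the limit of > 100000 nM in this assay, at which 3 of the 4 values shown sit.

Open remains how compound 1, compound 3 and compound 4 actually compare in this read-out.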